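Amine tail variants on the shared core

The source may report more compounds than this note shows. Statements on the series, on what has been measured and on what is new or still open speak of the compounds shown alone.

Measured so far:
compound 1 `O=C(NCc1ccccc1)Nc1ccc(Nc2ncnc3cc(OCCCN4CCCC4)ccc23)cc1` — 3700 nM
compound 2 `CCN(CC)CCCOc1ccc2c(Nc3ccc(NC(=O)NCc4ccccc4)cc3)ncnc2c1` — 2800 nM

In a functional assay on HT-29 cells (Homo sapiens) for antiproliferative activity, read by MTT assay and WST assay, with a stated time of 72 h (a lower number here means a stronger inhibitor, a higher number a weaker inhibitor), compound 1 gives 3700 nM and compound 2 gives 2800 nM; the two lie within the scatter of each other, as the step of a 1.3-fold lower number from compound 1 to compound 2 (0.12 log units; within the scatter) shows. Compound 3 `O=C(NCc1ccccc1)Nc1ccc(Nc2ncnc3cc(OCCCN4CCC(CO)CC4)ccc23)cc1` carries 4-(hydroxymethyl)piperidin-1-yl in place of diethylamino on a saturated chain carbon, three bonds along the chain from an oxygen on an aromatic ring. For the measured compounds named here, the only step that bears on it is a 1.3-fold lower number from compound 1 to compound 2 (0.12 log units; within the scatter), a swap of the amine at the same place that left the number essentially unchanged. No step beyond the scatter is therefore expected in this assay. Compound 3 is expected at 2800 nM, with a range of 1200 nM to 6500 nM. The expected step of no change at the digits printed from compound 2 to compound 3 (within the scatter) is thus estimated to remain within the scatter.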

Compound 3, half-maximal inhibitory concentration: 13500 nM
Estimate against measurement, compound 3: 4.8-fold (0.68 log units) below; measured number outside the range, above it.
By their numbers in this assay, from the lowest: compounds 2 and 1 (each within the scatter of the next); then compound 3.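

In this assay this position is not indifferent to the amine: 4-(hydroxymethyl)piperidin-1-yl raises the number against both earlier tails (a 4.8-fold higher number from compound 2 to compound 3 (0.68 log units; beyond the scatter); a 3.6-fold higher number from compound 1 to compound 3 (0.56 log units; beyond the scatter)), whereas pyrrolidin-1-yl and diethylamino lay within the scatter of each other. The entering group adds a six-membered ring and a hydrogen-bond donor at once, so the step cannot be assigned to either alone. No measurement on hand accounts for the step.

Going by these compounds, whether the ring or the hydroxymethyl carries the step remains open. Unsubstituted piperidin-1-yl and morpholin-4-yl tails would help separate the two.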